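This account rests on a few compounds, and the source may have more. Where it says the series, first, only, none or still open, it means among the compounds named here.

Measured compounds in an assay on HEK293 cells for activation of cGMP-dependent protein kinase 1 (Homo sapiens), read by HTRF, with a stated time of 3 h; a higher number here means that more compound is needed for the effect, a lower number that less compound is needed:
- compound 1 `OC[C@@H](O[C@H]1CCCN(Cc2ncc[nH]2)[C@H]1c1ccccc1)c1cc(Cl)cc(Cl)c1` gives 8800 nM
- compound 2 `O=C(O)c1ccc(CN2CCC[C@H](O[C@H](CO)c3cc(Cl)cc(Cl)c3)[C@@H]2c2ccccc2)cc1` gives 15000 nM

Going by the values given here, compound 1 has the lower of the two numbers measured so far, but the step of a 1.7-fold higher number from compound 1 to compound 2 (0.23 log units; within the scatter) falls within the scatter, so the two compounds cannot be told apart in this assay. Compound 3 `Clc1cc(Cl)cc(CO[C@H]2CCCN(Cc3ncc[nH]3)[C@H]2c2ccccc2)c1` has not yet been measured. It differs from compound 1 in one place: hydrogen in place of hydroxymethyl on a saturated chain carbon bound to an aromatic carbon and an oxygen on a saturated carbon. Among the compounds with values here, the only measured step concerns a change on a different part of the shared core, so it gives no guidance on what happens when the hydroxymethyl is removed. With nothing in the data to anchor it, the expectation is that compound 3 shows a step of a 1.4-fold higher number from compound 1 to compound 3 (0.13 log units; within the scatter) that stays close to compound 1, with wide uncertainty. Compound 3 is therefore estimated at 12000 nM in this assay, with a range from 4000 nM to 40000 nM.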

Compound 3, half-maximal effective concentration: > 164000 nM
Compound 3: only a limit was reported; the forecaster's own chance of this, stated with the estimate: 15%; middle value at least 13-fold (1.13 log units) from the limit.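

Taking away the hydroxymethyl on a saturated chain carbon bound to an aromatic carbon and an oxygen on a saturated carbon is the first change here that clearly moves the result in this assay, with an at least 18-fold higher number from compound 1 to compound 3 (1.27 log units; beyond the scatter). Compound 3 is reported only as a limit and not as a number: the limit of > 164000 nM in this assay, at which 1 of the 3 values shown sits. The earlier change on a saturated chain carbon bound to an amine nitrogen in a ring, a 1.7-fold higher number from compound 1 to compound 2 (0.23 log units; within the scatter), could not be told from scatter, so among these compounds only the change at the hydroxymethyl position has a clear effect.

The compounds shown carry only hydroxymethyl or hydrogen at this position, so it stays open whether a methyl, a methoxymethyl or an aminomethyl would hold the value of compound 1. From the compounds shown here alone, it also stays open whether the same large step would appear with the 4-carboxyphenyl of compound 2.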